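The source may hold more compounds than are shown below. What is called first, only, known or untested is meant among the compounds shown, and "the series" means these compounds.

Compound 1 `CCCOC(=O)c1cc(N2C(=O)C3=C(CCCC3)C2=O)ccc1Cl`: 1860 nM
Compound 2 `CCC(C)OC(=O)c1cc(N2C(=O)C3=C(CCCC3)C2=O)ccc1Cl`: 794 nM

Both values come from a functional assay on the whole organism with Scenedesmus acutus as the target; on this read-out lower numbers stand for stronger inhibition and higher numbers for weaker inhibition. Compound 2, at 794 nM, has the lower number of the pair, which makes it the stronger inhibitor of the two. The compound still to be measured is compound 3 `CCCCCCCCOC(=O)c1cc(N2C(=O)C3=C(CCCC3)C2=O)ccc1Cl`. It differs from compound 2 as follows: octyl in place of sec-butyl on an oxygen next to a carbonyl group. In words, it has octyl in place of sec-butyl on an oxygen next to a carbonyl group.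

Among the compounds with values here, only one measured step bears on this change: a 2.3-fold lower number from compound 1 to compound 2 (0.37 log units; beyond the scatter). That step is modest. It altered the chain on the same oxygen, but only by adding a methyl, so it says little about a chain as long as octyl. Octyl is unbranched, like the chain of compound 1, yet it is longer than the chain of compound 2. These two comparisons give no clear direction, so no step beyond the scatter is expected, though the uncertainty is wide. The expected step is a 1.3-fold higher number from compound 2 to compound 3 (0.10 log units; within the scatter). The estimate for compound 3 is 1000 nM, with an expected range from 200 nM to 5000 nM.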

Compound 3, half-maximal inhibitory concentration: > 100000 nM
Compound 3: a limit, no number; the forecaster's own chance of this, stated with the estimate: 5%; middle value at least 100-fold (2.00 log units) away from the limit.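

In this assay compound 3 gives no number, only a limit of the assay: the limit of > 100000 nM in this assay, at which 1 of the 3 values shown sits. This position, on an oxygen next to a carbonyl group, does not accept every chain: octyl in place of sec-butyl gives an at least 120-fold higher number from compound 2 to compound 3 (2.10 log units; beyond the scatter), and the longer unbranched chain gives an at least 53-fold higher number from compound 1 to compound 3 (1.73 log units; beyond the scatter). Both steps are large, whereas the earlier pair showed only a modest change, a 2.3-fold lower number from compound 1 to compound 2 (0.37 log units; beyond the scatter), so the chain on this oxygen can decide whether the read-out yields a number at all.

The compounds shown leave open at what length between the chain of compound 1 and octyl the number starts to climb, which a pentyl or hexyl chain on the same oxygen would help to locate, and whether a branched chain as long as octyl would behave like compound 3. They also leave open whether length alone matters, which a chain of similar length ending in a hydroxyl group or an amine would begin to test.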